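Shortening the Acid-Bearing Chain on a Shared Core

The source may report more compounds than this note shows. Statements on the series, on what has been measured and on what is new or still open speak of the compounds shown alone.

Three compounds built on one core have been examined in an assay (Cricetulus griseus) for inhibition of Monoamine oxidase (Homo sapiens); on this read-out lower numbers stand for stronger inhibition and higher numbers for weaker inhibition. Compound 2 `O=C(O)CCCCOc1ccc2c(=O)c(-c3ccc(O)cc3)coc2c1` gives 5000 nM and is the only one of the three with a number. Compound 1 `NCCCCCCOc1ccc2c(=O)c(-c3ccc(O)cc3)coc2c1` gives only a limit, >> 9000 nM. Compound 3 `O=c1c(-c2ccc(O)cc2)coc2cc(OCCCCCCO)ccc12` likewise gives only a limit, > 9000 nM. The step of an at least 1.8-fold lower number from compound 1 to compound 2 (0.25 log units; that floor lies within the scatter) and the step of an at least 1.8-fold higher number from compound 2 to compound 3 (0.25 log units; that floor lies within the scatter) are therefore each read against a limit, and a step that the two limits leave unreadable from compound 1 to compound 3 cannot be read at all.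

Compound 4 `O=C(O)COc1ccc2c(=O)c(-c3ccc(O)cc3)coc2c1` has not yet been measured in this assay. It differs from compound 2 in carboxy in place of 3-carboxypropyl on a saturated chain carbon bound to an oxygen on an aromatic ring: the acid is kept, but the chain between it and the ring oxygen is cut away. Within the data shown here, none of the measured steps alters the chain length; the two that can be read, an at least 1.8-fold lower number from compound 1 to compound 2 (0.25 log units; that floor lies within the scatter) and an at least 1.8-fold higher number from compound 2 to compound 3 (0.25 log units; that floor lies within the scatter), exchange only the end group while the chain stays, and both rest on limits. Since the carboxy end is retained, the step is expected to stay within the scatter or to drift toward weaker inhibition, a 1.4-fold higher number from compound 2 to compound 4 (0.15 log units; within the scatter). Compound 4 is therefore estimated at 7000 nM, within 2500 nM to 20000 nM, with a real chance that this assay again returns only a limit.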

Compound 4, half-maximal inhibitory concentration: >> 9000 nM
Compound 4: a limit, no number (the forecaster's own chance of this, stated with the estimate: 40%); middle value at least 1.2-fold (0.10 log units) away from the limit.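

Shortening 3-carboxypropyl to carboxy, on a saturated chain carbon bound to an oxygen on an aromatic ring, gives an at least 1.8-fold higher number from compound 2 to compound 4 (0.25 log units; that floor lies within the scatter). Among these compounds, this is the first step that changes the chain rather than the end group, and it shows that keeping the carboxy end does not by itself preserve a numerical reading in this assay: of the four compounds, only compound 2, with its 4-carboxybutoxy group, has one. Compound 4 gives a limit and no number, so how far its true value lies from that of compound 2 remains unread, and this limit is a common result in the series: the limit of >> 9000 nM in this assay, at which 2 of the 4 values shown sit.

The steps to compound 4 from compound 1 and from compound 3 each run between two limits and cannot be read. The compounds shown leave open whether a carboxylic acid on a chain longer than 4-carboxybutyl, or a methyl ester on the 4-carboxybutyl chain in place of the acid, would give a number in this assay.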